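The compounds below may be only part of what the source reports. "The series", "measured", "known", "first", "only" and "open" are said of these compounds alone.

Within the data shown here, in a physicochemical assay, read by spectrophotometry, with a stated time of 25 min (on this read-out lower numbers stand for stronger inhibition and higher numbers for weaker inhibition), compound 2 `O=c1cc(-c2ccccc2)oc2cc(OCCCCNc3nc4ccc(F)cc4s3)cc(O)c12` gives 14.7 ug/mL, and its only measured neighbour, compound 1 `O=c1cc(-c2ccccc2)oc2cc(OCCCCNc3nc4ccccc4s3)cc(O)c12`, gives 26.5 ug/mL in this assay, a gap that the step of a 1.8-fold lower number from compound 1 to compound 2 (0.26 log units; within the scatter) shows lies within the scatter. Compound 3 `O=C(O)c1ccc2nc(NCCCCOc3cc(O)c4c(=O)cc(-c5ccccc5)oc4c3)sc2c1` differs from compound 2 by carboxy in place of fluoro on an aromatic carbon. Among the measured compounds shown here, no measured step tests a carboxy group here, and the single known change did not move the number beyond the scatter. The expected step for compound 3 is therefore a 1.2-fold higher number from compound 2 to compound 3 (0.09 log units; within the scatter). Compound 3 is estimated at 18 ug/mL, with a range from 7 ug/mL to 45 ug/mL.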

Compound 3, half-maximal inhibitory concentration: 21.7 ug/mL
The estimate for compound 3 lay 1.2-fold (0.08 log units) below the measured number; low and high end bracket the measured number.
By their numbers in this assay, from the lowest: compounds 2, 3 and 1 (each within the scatter of the next).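

Carboxy in place of fluoro gives a 1.5-fold higher number from compound 2 to compound 3 (0.17 log units; within the scatter) and carboxy in place of hydrogen gives a 1.2-fold lower number from compound 1 to compound 3 (0.09 log units; within the scatter) on the same aromatic carbon. Both steps stay within the scatter in this assay so hydrogen, fluoro and carboxy cannot be told apart here, even though carboxy brings more heavy atoms and a hydrogen-bond donor. No supporting measurement is available to explain this result. From the compounds shown here alone, whether an amine or a methoxy group on this carbon would also stay within the scatter remains open, as does the effect of a longer linking chain.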